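The compounds below may be only part of what the source reports. "The series", "measured", "known", "first", "only" and "open" are said of these compounds alone.

Measured so far in an assay on tissue (RPTEC cells) for inhibition of solute carrier family 22 member 12 (Homo sapiens), read by scintillation counting, with stated times of 15 min and 2 h; a higher number here means a weaker inhibitor, a lower number a stronger inhibitor:
Compound 1 `N#Cc1cc(C(=O)N2CCc3ccccc32)cc(Cl)c1O`: 14700 nM
Compound 2 `N#Cc1cc(C(=O)N2CCc3ccccc32)cc(C(F)(F)F)c1O`: > 100000 nM (a limit of the assay, not a number)
Compound 3 `COc1cc(C(=O)N2CS(=O)(=O)c3ccccc32)cc(C(F)(F)F)c1O`: 17800 nM

Compound 2 sits at the limit of > 100000 nM in this assay, at which 1 of the 3 values shown sits, so its result is a limit rather than a number. Compound 1 and compound 3 give numbers that lie within the scatter of each other. Compound 1 differs from compound 2 in one place, (chloro in place of trifluoromethyl on an aromatic carbon), and the step of an at least 6.8-fold lower number from compound 2 to compound 1 (0.83 log units; beyond the scatter) is at least modest in this assay. Compound 3 differs from compound 2 in more than one place; the difference between the two cores is not broken down here.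

Compound 4 `COc1cc(C(=O)N2CS(=O)(=O)c3ccccc32)cc(Cl)c1O` has not been measured. It differs from compound 3 by chloro in place of trifluoromethyl on an aromatic carbon. This is the same kind of change as that from compound 2 to compound 1, but not the same: here the carbon carrying the change is meta to a methoxy group, whereas there it was meta to a cyano group. The expectation for compound 4 rests on an at least 6.8-fold lower number from compound 2 to compound 1 (0.83 log units; beyond the scatter), which is known only as a bound. A step of a 3.6-fold lower number from compound 3 to compound 4 (0.55 log units; beyond the scatter) is therefore expected in this assay. Compound 4 is estimated at 5000 nM, between 1500 nM and 17000 nM.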

Compound 4, half-maximal inhibitory concentration: 4300 nM
For compound 4 the middle estimate is 1.2-fold (0.07 log units) above the measured one; the range from low to high includes it.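

In this assay, chloro in place of trifluoromethyl on an aromatic carbon gives a 4.1-fold lower number from compound 3 to compound 4 (0.62 log units; beyond the scatter). The change goes in the same direction on both cores shown: the same change on two cores in this assay, an at least 6.8-fold lower number (0.83 log units; beyond the scatter) from compound 2 to compound 1 and a 4.1-fold lower number (0.62 log units; beyond the scatter) from compound 3 to compound 4; the limit leaves it open whether they differ Compound 2 gives > 100000 nM, which is a limit of the assay and not a number, so the size of the step on that core stays unknown, and the two pairs show a shared direction but not a shared size.

The compounds shown leave open whether a group other than chloro or trifluoromethyl on that aromatic carbon, such as bromo or methyl, would follow the same direction. They also leave open whether the step would hold with an amine or a longer alkoxy chain in place of the methoxy group, or with a carboxylic acid in place of the hydroxy group that all four compounds share.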